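A few compounds are considered here, and "the series" means these few. Any claim that something is new, unique, unknown or untested is made for them only; others in the source may bear on it.

Measured so far:
compound 1, `Cc1ccccc1S(=O)(=O)Nc1ccc(-c2nc3ccccc3o2)cc1`, > 63000 nM
compound 2, `O=S(=O)(Nc1ccc2oc(-c3ccccc3)nc2c1)c1ccc(F)c(C(F)(F)F)c1`, > 63000 nM

Two sulfonamides have been run in an assay on isolated protein for inhibition of malate dehydrogenase, mitochondrial (Sus scrofa), with stated times of 45 min and 30 min; a lower number here means a stronger inhibitor, a higher number a weaker inhibitor. For compound 1 the result is only a limit of the assay, > 63000 nM. For compound 2 the result is likewise a limit, > 63000 nM. Both sit at the limit of > 63000 nM in this assay, at which 2 of the 2 values shown sit, so compound 1 stands nowhere on a measured scale; it is simply not seen as an inhibitor within the tested range.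

Compound 3, `COc1ccccc1S(=O)(=O)Nc1ccc(-c2nc3ccccc3o2)cc1`, differs from compound 1 by methoxy in place of methyl on an aromatic carbon. Going by the values given here, with no measured step to draw on, and compound 1 already beyond the limit, the change is expected to move this assay by little or nothing beyond the scatter: the step that the limit leaves unreadable from compound 1 to compound 3 is estimated to be flat. Compound 3 is therefore expected to give about 80000 nM, within 20000 nM to 300000 nM, most likely reported as a limit again.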

Compound 3, half-maximal inhibitory concentration: > 63000 nM
Compound 3: only a limit was reported (the forecaster's own chance of this, stated with the estimate: 85%); the middle value does not contradict the limit.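

No step can be read between compound 1 and compound 3, because both stop at the same limit: the limit of > 63000 nM in this assay, at which 3 of the 3 values shown sit.

The compounds shown leave open how methoxy and methyl compare, and which change would bring a value within the measurable range.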